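The source may hold more compounds than are shown below. What is called first, only, known or untested is meant among the compounds shown, and "the series" means these compounds.

Measured compounds in an ADME assay on cells (Peritoneal macrophage, Mus musculus, strain Balb/c) for cytotoxicity, read by resazurin assay, with a stated time of 72 h; a higher number here means that more compound is tolerated, a lower number that less compound is tolerated:
Compound 1 `CC1(Cc2ccc(/C(N)=N/O)cc2)CC(S(=O)(=O)c2ccc(F)cc2)=C(c2ccc(/C(N)=N/O)cc2)O1` gives 42200 nM.
Compound 2 `CC1(Cc2ccc(C(F)(F)F)cc2)CC(S(=O)(=O)c2ccc(F)cc2)=C(c2ccc(/C(N)=N/O)cc2)O1` gives 103000 nM.
Compound 3 `Cc1ccccc1CC1(C)CC(S(=O)(=O)c2ccc(F)cc2)=C(c2ccc(/C(N)=N/O)cc2)O1` gives 77600 nM.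

Among these three numbers compound 3 sits in the middle, with compound 2 nearest and compound 1 furthest, and its steps to both lie within the scatter. Compound 4 `CC1(Cc2cccc(CO)c2)CC(S(=O)(=O)c2ccc(F)cc2)=C(c2ccc(/C(N)=N/O)cc2)O1` differs from compound 3 by 3-(hydroxymethyl)phenyl in place of 2-methylphenyl on a saturated chain carbon bound to a saturated ring carbon. Among the measured compounds shown here, two measured steps touch the same place: a 1.8-fold higher number from compound 1 to compound 3 (0.26 log units; within the scatter) and a 1.3-fold lower number from compound 2 to compound 3 (0.12 log units; within the scatter), and neither leaves the scatter, so swapping this outer ring has so far hardly moved the number. For compound 4 no step beyond the scatter is therefore expected, a 1.1-fold lower number from compound 3 to compound 4 (0.04 log units; within the scatter). Compound 4 is estimated at 70000 nM, with a range from 30000 nM to 150000 nM.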

Compound 4, half-maximal cytotoxic concentration: > 100000 nM
Compound 4: only a limit was reported (the forecaster's own chance of this, stated with the estimate: 15%); middle value at least 1.4-fold (0.15 log units) away from the limit.
By their numbers in this assay, from the lowest: compounds 1, 3 and 2 (each within the scatter of the next, the first and the last beyond it).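

In this assay compound 4 gives only a limit, not a number: the limit of > 100000 nM in this assay, at which 1 of the 4 values shown sits.

Measured against the other outer rings, this change gives an at least 1.2-fold higher number from compound 3 to compound 4 (0.11 log units; that floor lies within the scatter), and an at least 2.3-fold higher number from compound 1 to compound 4 (0.37 log units; beyond the scatter), so the oxygen that compound 4 and compound 1 both carry in this group does not alone bring the lower number of compound 1. The step from compound 2 to compound 4 cannot be read.

Going by these compounds, how far compound 4 lies past its limit stays open, as does whether an amine, a carboxylic acid or a longer chain in this place would be tolerated as well.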